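Swapping the Aryl Group on a Cinnamate Ester

A few compounds are considered here, and "the series" means these few. Any claim that something is new, unique, unknown or untested is made for them only; others in the source may bear on it.

Measured so far:
Compound 1, `COc1cc(OC)c(OC)cc1/C=C/COC(=O)/C=C/c1c(OC)ccc(OC)c1OC`, activity 75%
Compound 2, `COc1cc(OC)c(OC)cc1/C=C/COC(=O)/C=C/c1ccccc1C(F)(F)F`, activity 75%
Compound 3, `COc1cc(OC)c(OC)cc1/C=C/COC(=O)/C=C/c1ccc(OC)c(OC)c1OC`, activity 75%

In a functional assay on the whole organism (strain Kunming) with Mus musculus as the target, with a stated time of 0.5 h, at a dose of 300 mg/kg by the intraperitoneal route (a higher number here means a weaker effect of the compound at the dose given, a lower number a stronger effect), compound 2 stands level with compound 1 and compound 3 at the digits shown; these three values lie within the usual scatter of each other, so no order among them can be claimed. Compound 4, `COc1cc(OC)c(OC)cc1/C=C/COC(=O)/C=C/c1ccc(Cl)cc1`, is not yet measured. It differs from compound 2 by 4-chlorophenyl in place of 2-(trifluoromethyl)phenyl on a double-bonded chain carbon bound to a double-bonded chain carbon. Among the compounds with values here, no step between measured compounds is available to size this change. Because compound 1 gives 75% and compound 3 gives 75% with quite different aryl groups, a step from compound 2 to compound 4 of no size beyond the scatter is expected in this assay, namely no change at the digits printed from compound 2 to compound 4 (within the scatter). Compound 4 is estimated at 75%, with a range from 50% to 100%.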

Compound 4, a percentage reported as activity, at one dose (the size of the read-out at that dose, not a potency): 50%
Compound 4: the middle estimate sits 25 percentage points above what was measured; the measured number falls inside the stated range.
By their numbers in this assay, from the lowest: compound 4; then compounds 1, 2 and 3 (each within the scatter of the next).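

In this assay, putting 4-chlorophenyl in place of 2-(trifluoromethyl)phenyl gives a number 25 percentage points lower from compound 2 to compound 4 (beyond the scatter), so this aryl position can respond to a change, which the level values of compounds 1, 2 and 3 gave no sign of. Compound 4 shows the stronger effect at the dose given. Nothing here explains the step. Since the substituent and its place on the ring both differ, the compounds shown cannot say which of the two matters. Going by these compounds, a 2-chlorophenyl or 4-(trifluoromethyl)phenyl group would separate them, and an amine or a carboxylic acid on the ring remains untested here.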